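Sulfone Tetrahydronaphthalene Series: From Hydroxyazetidine to Sulfonamide

This account rests on a few compounds, and the source may have more. Where it says the series, first, only, none or still open, it means among the compounds named here.

Measured compounds:
Compound 1, `COc1cccc(S(=O)(=O)c2ccc3c(c2)CCC[C@H]3CN)c1`, an assay on isolated protein for displacement of a labelled ligand from 5-hydroxytryptamine receptor 6 (Homo sapiens); on this read-out lower numbers stand for stronger inhibition and higher numbers for weaker inhibition: 0.398 nM
Compound 2, `O=S(=O)(c1cccc(F)c1)c1ccc2c(c1)CCC[C@H]2CN1CC(O)C1`, this assay: 0.1 nM

Of the compounds shown here, two have been measured in this assay. Compound 1 gives 0.398 nM in this assay, and compound 2 gives 0.1 nM. Compound 2 thus holds the lowest number of the two, and its distance to compound 1 lies beyond the usual scatter of this assay, so compound 2 reads as the stronger of the pair.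

The next compound, compound 3, `CN(C[C@@H]1CCCc2cc(S(=O)(=O)c3cccc(F)c3)ccc21)S(C)(=O)=O`, differs from compound 2 in one place: methyl(methylsulfonyl)amino in place of 3-hydroxyazetidin-1-yl on a saturated chain carbon bound to a saturated ring carbon. Within the data shown here, no measured pair in this set shares this change, so no reference step exists for it. The two measured compounds, compound 1 with 0.398 nM and compound 2 with 0.1 nM, both carry a nitrogen on the saturated chain carbon, and both return low numbers; compound 3 keeps a nitrogen there but within a different group.

In this assay, the step from compound 2 to compound 3 is expected to be upward by a 150-fold higher number from compound 2 to compound 3 (2.18 log units; beyond the scatter), beyond the scatter. Compound 3 is therefore estimated at 15 nM, within a range from 2 nM to 120 nM.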

Compound 3, inhibition constant: 0.398 nM
Compound 3: the middle estimate sits 38-fold (1.58 log units) above what was measured, and the stated range ends above it.
By their numbers in this assay, from the lowest: compound 2; then compounds 1 and 3 (each within the scatter of the next).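

In this assay, putting methyl(methylsulfonyl)amino in place of 3-hydroxyazetidin-1-yl on a saturated chain carbon bound to a saturated ring carbon gives a 4.0-fold higher number from compound 2 to compound 3 (0.60 log units; beyond the scatter), a modest step that is nonetheless beyond the usual scatter. This shows that the position can lose the four-membered ring and the hydrogen-bond donor of the 3-hydroxyazetidin-1-yl group and take an open group carrying a sulfur, with compound 3 still at 0.398 nM. No measurement shown here accounts for the size of this step.

The ring, the hydroxyl and the sulfonyl all change in this single exchange, so the compounds shown do not say which of these parts accounts for the step from the 3-hydroxyazetidin-1-yl group. An unsubstituted azetidine would separate the hydroxyl from the ring at this place, and a methyl(acetyl)amino group would put a carbonyl where compound 3 has its sulfonyl, but neither group stands among the compounds shown.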